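Swapping an Aryl Group for an Aryloxy Group

A few compounds are considered here, and "the series" means these few. Any claim that something is new, unique, unknown or untested is made for them only; others in the source may bear on it.

Measured compounds:
- compound 1, `COc1cccc(N(C)C(=O)C2CCC(c3ccc(Cl)cc3)CC2)c1`, 290 nM
- compound 2, `COc1cccc(N(C)C(=O)c2ccc(-c3ccc(C)c(C)c3)cc2)c1`, 300 nM

Of the compounds shown here, two have been tested in an assay on microsomes from placenta for inhibition of 17-beta-hydroxysteroid dehydrogenase type 2 (Homo sapiens), read by HPLC, with a stated time of 20 min; on this read-out lower numbers stand for stronger inhibition and higher numbers for weaker inhibition. Compound 1 gives 290 nM, and compound 2 gives 300 nM. These two numbers sit within the usual scatter of each other, so compound 2 has the higher of the two numbers only in the narrowest sense; on the data shown, the two compounds cannot be told apart.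

Compound 3, `COc1ccc(Oc2ccc(C(=O)N(C)c3cccc(OC)c3)cc2)cc1`, has not yet been measured. It differs from compound 2 in one place: 4-methoxyphenoxy in place of 3,4-dimethylphenyl on an aromatic carbon. The shared amide and the methoxyphenyl part on the nitrogen stay the same; only the outer ring and its link to the core change.

Going by the values given here, no measured pair shows what this kind of exchange does here, so there is no step to lean on. With compound 2 at 300 nM as the starting point, a step from compound 2 to compound 3 of about a 1.3-fold higher number from compound 2 to compound 3 (0.12 log units; within the scatter) is expected, that is, little change, with the outcome as likely within the scatter as beyond it. Compound 3 is therefore estimated at 400 nM, with a range from 120 nM to 1300 nM.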

Compound 3, half-maximal inhibitory concentration: 310 nM
Compound 3: the middle estimate sits 1.3-fold (0.11 log units) above what was measured; measured number inside the range.
By their numbers in this assay, from the lowest: compounds 1, 2 and 3 (each within the scatter of the next).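

Going by these compounds alone, putting 4-methoxyphenoxy in place of 3,4-dimethylphenyl on this aromatic carbon, para to a large group, gives a 1.0-fold higher number from compound 2 to compound 3 (0.01 log units; within the scatter) in this assay as the first step that can be read in this set. So this position accepts an outer ring joined through an oxygen and carrying a methoxy group, and compound 3 cannot be told apart from compound 2 on these data. The count of hydrogen-bond acceptors in the group goes from 0 to 2 and the entering group is one heavy atom larger, yet the difference between the two compounds stays within the usual scatter of this kind of measurement.

This single exchange alters the link and the groups on the outer ring together, so the compounds shown leave open what each alteration does alone, and whether the two effects are both small or offset each other, as well as whether a carboxylic acid, an amine or a plain phenoxy group at this position would also stay within the scatter. Nothing at hand gives a reason for this result.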